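Swapping ethyl for cyclopropyl on an aromatic nitrogen

The source may report more compounds than this note shows. Statements on the series, on what has been measured and on what is new or still open speak of the compounds shown alone.

In a functional assay on KG-1 cells (Homo sapiens) for antiproliferative activity, read by CCK-8 assay, with a stated time of 72 h (a lower number here means a stronger inhibitor, a higher number a weaker inhibitor), compound 1 `Cc1ccc(C(=O)Nc2cccc(C(F)(F)F)c2)cc1-c1ccc2c(-c3ccc(N4CCN(C)CC4)cc3)n[nH]c2c1` gives 136 nM and compound 2 `CCn1cc(-c2n[nH]c3cc(-c4cc(C(=O)Nc5cccc(C(F)(F)F)c5)ccc4C)ccc23)cn1` gives 257 nM so the two numbers lie within the usual scatter of repeated measurements. Compound 2 therefore cannot be ranked apart from compound 1 on this evidence. Among the compounds with values here, these are the only two numbers available, and no pair of measured compounds differs in one place alone, so no measured step can guide a prediction.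

Compound 3 `Cc1ccc(C(=O)Nc2cccc(C(F)(F)F)c2)cc1-c1ccc2c(-c3cnn(C4CC4)c3)n[nH]c2c1` is compound 2 with a single change: cyclopropyl in place of ethyl on an aromatic nitrogen and the rest of the structure is untouched. The best starting point for a prediction is therefore compound 2 at 257 nM as its closest measured relative. With no measured evidence for a shift in either direction, no change beyond the scatter is expected in this assay and the estimated move is a 1.2-fold lower number from compound 2 to compound 3 (0.09 log units; within the scatter) as a step too small to call real. Compound 3 is expected at 210 nM (estimated range 90 nM to 500 nM).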

Compound 3, half-maximal inhibitory concentration: 108 nM
Compound 3: the middle estimate sits 1.9-fold (0.29 log units) above what was measured; low and high end bracket the measured number.
By their numbers in this assay, from the lowest: compounds 3, 1 and 2 (each within the scatter of the next, the first and the last beyond it).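

In this assay, within the data shown here, replacing the 1-ethyl-1H-pyrazol-4-yl group with the 1-cyclopropyl-1H-pyrazol-4-yl group gives a 2.4-fold lower number from compound 2 to compound 3 (0.38 log units; beyond the scatter) as the first step in this set that can be read between two compounds differing in one place alone. The step is modest, yet it lies beyond the usual scatter, so the group on this aromatic nitrogen does affect the read-out and is not a spot where any small carbon group gives the same number. The change is a narrow one: neither ethyl nor cyclopropyl carries a hydrogen-bond donor, a hydrogen-bond acceptor or a net charge, and the rest of the structure stays the same.

This single step gives a direction for one swap but no trend across this position, and methyl, isopropyl, cyclobutyl or a longer chain such as propyl on the same nitrogen would be needed to show whether the number keeps moving or whether the three-membered ring itself matters. Nothing among the available measurements explains why the cyclopropyl compound gives the lower number.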